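Methoxy on the aryl ether ring, carried from one core to another

A few compounds are considered here, and "the series" means these few. Any claim that something is new, unique, unknown or untested is made for them only; others in the source may bear on it.

Compound 1 `C=C(C)[C@@H]1CC=C(Cn2cc(COc3ccc(C4NC(=O)NC(C)=C4C(=O)OCC)cc3)nn2)CC1` gives 19200 nM in a functional assay on UACC-62 cells (Homo sapiens) for inhibition, read by sulforhodamine B assay, with a stated time of 48 h; on this read-out lower numbers stand for stronger inhibition of growth and higher numbers for weaker inhibition of growth. Compound 2 `C=C(C)[C@@H]1CC=C(Cn2cc(COc3ccc(C4NC(=O)NC(C)=C4C(=O)OCC)cc3OC)nn2)CC1` gives 26700 nM in this assay. The change between them, (methoxy in place of hydrogen on an aromatic carbon), made a 1.4-fold higher number from compound 1 to compound 2 (0.14 log units; within the scatter). Compound 3 `C=C(C)[C@@H]1CC=C(Cn2cc(COc3cccc(C4NC(=O)NC(C)=C4C(C)=O)c3)nn2)CC1` has a different core; how the two cores differ is not broken down here. In this assay compound 3 gives 31600 nM. Compound 4 `C=C(C)[C@@H]1CC=C(Cn2cc(COc3cc(C4NC(=O)NC(C)=C4C(C)=O)ccc3OC)nn2)CC1` carries the same kind of change on the core of compound 3, (methoxy in place of hydrogen on an aromatic carbon); around the place, the entering group stands para to a large group here, where in compound 2 it stood meta to a large group. The expected step is a 1.3-fold higher number from compound 3 to compound 4 (0.10 log units; within the scatter), set beside the earlier change, because a 1.4-fold higher number from compound 1 to compound 2 (0.14 log units; within the scatter) stayed within the scatter. Compound 4 is estimated at 40000 nM, in a range from 20000 nM to 80000 nM.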

Compound 4, concentration for total growth inhibition: > 100000 nM
Compound 4: only a limit was reported; the forecaster's own chance of this, stated with the estimate: 10%; middle value at least 2.5-fold (0.39 log units) away from the limit.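

Carried to the other core, methoxy in place of hydrogen on an aromatic carbon gives an at least 3.1-fold higher number from compound 3 to compound 4 (0.50 log units; beyond the scatter) in this assay. Compound 4 reads > 100000 nM, which is a limit of the assay and not a number, so the step has no upper bound. The core and the place of the methoxy change together across the two pairs, and the data do not show that the effect of the change depends on the core: the same change on two cores in this assay, a 1.4-fold higher number (0.14 log units; within the scatter) from compound 1 to compound 2 and an at least 3.1-fold higher number (0.50 log units; beyond the scatter) from compound 3 to compound 4; the limit leaves it open whether they differ

Still open, on these data alone, is how a hydroxyl or a fluorine at the same place would read on either core. Also open, as far as these compounds go, is whether methoxy at the same place on the ring gives the same step on both cores.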